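Acetamido for dimethylamino on the anilino ring

This account rests on a few compounds, and the source may have more. Where it says the series, first, only, none or still open, it means among the compounds named here.

Measured compounds:
compound 1, `CC(=O)Nc1cccc(Nc2nccc(-c3cccnc3)n2)c1`, 3600 nM
compound 2, `CN(C)c1cccc(Nc2nccc(-c3ccncc3)n2)c1`, 3700 nM

Of the compounds shown here, two on a shared core have been measured in a functional assay for inhibition, with Homo sapiens as the target; a higher number here means a weaker inhibitor, a lower number a stronger inhibitor. Compound 1 gives 3600 nM in this assay, and compound 2 gives 3700 nM. These two numbers lie within the usual scatter of each other, so compound 2 cannot be placed apart from compound 1 on the numbers shown; no single-point comparison between them exists, since they differ in more than one place.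

Compound 3, `CC(=O)Nc1cccc(Nc2nccc(-c3ccncc3)n2)c1`, has not yet been measured. It differs from compound 2 in one place: acetamido in place of dimethylamino on an aromatic carbon. The acetamido group that enters here is the same group that compound 1 carries, and compound 1 gives 3600 nM, a number within the scatter of compound 2. On this basis compound 3 is expected to stay close to compound 2, with the step of a 1.1-fold lower number from compound 2 to compound 3 (0.02 log units; within the scatter) estimated at no more than the scatter in either direction. The estimate for compound 3 in this assay is 3500 nM, with a range from 1400 nM to 9000 nM.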

Compound 3, half-maximal inhibitory concentration: 2700 nM
Estimate against measurement, compound 3: 1.3-fold (0.11 log units) above, and the stated range covers the measured number.
By their numbers in this assay, from the lowest: compounds 3, 1 and 2 (each within the scatter of the next).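

In this assay, dimethylamino and acetamido can now be compared directly on the same aromatic carbon, with all else held constant, and replacing the first with the second gives only a small step (a 1.4-fold lower number from compound 2 to compound 3 (0.14 log units; within the scatter)). Thus, on the numbers shown, this position does not separate the two groups, even though acetamido carries a hydrogen-bond donor and a double bond outside aromatic rings that dimethylamino lacks. With acetamido held in place, pyridin-4-yl in place of pyridin-3-yl also gives a step that does not separate the two compounds (a 1.3-fold lower number from compound 1 to compound 3 (0.12 log units; within the scatter)), while no measurement shown bears on why either change leaves the number within the scatter.

The compounds shown leave open whether any group on this aromatic carbon would move the number beyond the scatter, for example a primary amine, a carboxylic acid or a longer acyl chain such as butanamido. They also leave open whether pyridin-2-yl in place of pyridin-4-yl, or a plain phenyl ring there, would behave like the two pyridinyl groups compared here.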